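Dichloro analogue of an inactive purine on breast cancer cells

The source may hold more compounds than are shown below. What is called first, only, known or untested is meant among the compounds shown, and "the series" means these compounds.

Compound 1 `ClCc1ccccc1Cn1cnc2ncnc(Cl)c21`: > 100000 nM
Compound 2 `Nc1nc(Cl)c2ncn(Cc3cccc(CCl)c3)c2n1`: 9550 nM

In a functional assay on MCF7 cells (Homo sapiens) for cytotoxicity, read by sulforhodamine B assay, with a stated time of 48 h (a lower number here means a stronger inhibitor of growth, a higher number a weaker inhibitor of growth), compound 1 gives only > 100000 nM, which is a limit of the assay and not a number. Compound 1 therefore stands at the limit of > 100000 nM in this assay, at which 1 of the 2 values shown sits. In this assay compound 2 gives 9550 nM.

Compound 3 `ClCc1ccccc1Cn1cnc2nc(Cl)nc(Cl)c21` differs from compound 1 by chloro in place of hydrogen on an aromatic carbon. For the measured compounds named here, no measured pair shows this change, so its effect is unknown; with compound 1 already at the limit, the step is expected to be modest and it may well stay beyond the limit. Compound 3 is estimated at 80000 nM (range 20000 nM to 300000 nM), a step of an at least 1.2-fold lower number from compound 1 to compound 3 (0.09 log units; that floor lies within the scatter).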

Compound 3, concentration for total growth inhibition: 2570 nM
Estimate against measurement, compound 3: 31-fold (1.49 log units) above; the measured number lies below the stated range.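

In this assay, for the compounds shown here, chloro in place of hydrogen on an aromatic carbon, between two ring nitrogen atoms, gives an at least 38-fold lower number from compound 1 to compound 3 (1.59 log units; beyond the scatter) as the only change. This position is therefore not silent: a single chlorine atom there takes the compound from a limit to a measured value. The true size of the step stays unknown, as its starting point is a limit of the assay and not a number: the limit of > 100000 nM in this assay, at which 1 of the 3 values shown sits.

Whether this gain is specific to chloro remains open, since neither a methyl nor a methoxy group appears at this position in the compounds shown.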